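Swapping a benzyloxy group for a direct aryl ring

The compounds below may be only part of what the source reports. "The series", "measured", "known", "first", "only" and "open" are said of these compounds alone.

The three measured compounds and their values in a functional assay on HEK293 cells for agonist activity at G-protein coupled receptor 39 (Homo sapiens), read by scintillation proximity assay and inositol phosphate accumulation, with a stated time of 75 min (a lower number here means that less compound is needed, a higher number that more compound is needed for the effect), are:
Compound 1 `Cc1nn(-c2ncnc3nc[nH]c23)c2c1C(C(=O)NCc1ccccc1)CC(=O)N2` gives 2930 nM.
Compound 2 `Cc1nn(-c2ncnc3nc[nH]c23)c2c1C(OCc1ccc(C#N)cc1)CC(=O)N2` gives 60 nM.
Compound 3 `Cc1nn(-c2ncnc3nc[nH]c23)c2c1C(OCc1ccc(F)cc1)CC(=O)N2` gives 126 nM.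

Compound 3 holds the second highest number of the three. Its nearest neighbour is compound 2, separated by a 2.1-fold higher number from compound 2 to compound 3 (0.32 log units; beyond the scatter), a modest step. Its furthest is compound 1, separated by a 23-fold lower number from compound 1 to compound 3 (1.37 log units; beyond the scatter), a large one.

Compound 4 `Cc1nn(-c2ncnc3nc[nH]c23)c2c1C(c1ccc(F)cc1Cl)CC(=O)N2` differs from compound 3 by a single change: 2-chloro-4-fluorophenyl in place of (4-fluorobenzyl)oxy on a saturated ring carbon. Among the compounds with values here, no measured step covers this kind of exchange, so only indirect guidance exists. The steps of a 49-fold lower number from compound 1 to compound 2 (1.69 log units; beyond the scatter) and a 23-fold lower number from compound 1 to compound 3 (1.37 log units; beyond the scatter) show that what sits on this saturated ring carbon can move the number a great deal, while a 2.1-fold higher number from compound 2 to compound 3 (0.32 log units; beyond the scatter) shows that the substituent on the aromatic ring matters less. Removing the oxygen and attaching the ring directly is a larger alteration than either, and its direction cannot be read from the data. A step of a 2.8-fold higher number from compound 3 to compound 4 (0.44 log units; beyond the scatter) toward a higher number is expected, with wide uncertainty. Compound 4 is therefore estimated at 350 nM, within a range of 60 nM to 2000 nM.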

Compound 4, half-maximal effective concentration: 280 nM
The estimate for compound 4 lay 1.3-fold (0.10 log units) above the measured number, within the range that was stated.
By their numbers in this assay, from the lowest: compound 2; then compound 3; then compound 4; then compound 1.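

Attached directly to the saturated ring carbon, a 2-chloro-4-fluorophenyl ring keeps most of the gain over the benzylcarbamoyl group of compound 1, with a 10-fold lower number from compound 1 to compound 4 (1.02 log units; beyond the scatter) in this assay, so the oxygen-containing link of the benzyloxy groups is not required for a low number. Losing that link costs only modestly, with a 2.2-fold higher number from compound 3 to compound 4 (0.35 log units; beyond the scatter) and, against the nitrile-bearing group, a 4.7-fold higher number from compound 2 to compound 4 (0.67 log units; beyond the scatter). No separate measurement bears on why the exchange has this effect.

This exchange removes the link and adds a chlorine in one step, so the compounds shown cannot separate the two contributions. From the compounds shown here alone, how an amine or a carboxylic acid on the aromatic ring, or a longer chain between that ring and the saturated ring carbon, would move the number also remains open.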